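The source may hold more compounds than are shown below. What is called first, only, known or untested is meant among the compounds shown, and "the series" means these compounds.

Measured so far in an assay on membranes from HeLa cells for displacement of a labelled ligand from adenosine receptor A3 (Homo sapiens), read by scintillation counting, with a stated time of 180 min, tested at 1 uM; a higher number here means more inhibition at the concentration tested (going by the name of the read-out), a lower number less inhibition:
compound 1 `CCCOC(=O)C1=C(C)NC(=O)NC1c1cccs1` gives 32%;
compound 2 `CC1=C(C(=O)OCC(C)C)C(c2cccs2)NC(=O)N1` gives 11%;
compound 3 `CCCOC(=O)C1=C(C)NC(=S)NC1c1ccoc1` gives 3%.

Within the data shown here, the one step that can be counted between measured compounds is a number 21 percentage points lower from compound 1 to compound 2 (beyond the scatter), made by the change (methyl in place of hydrogen on a saturated chain carbon bound to two saturated chain carbons). Compound 4 `CC1=C(C(=O)OCC(C)C)C(c2ccoc2)NC(=S)N1` is built from compound 3 by the same change, (methyl in place of hydrogen on a saturated chain carbon bound to two saturated chain carbons), at the same kind of place. The core of compound 3 differs from the core of compound 1, but that difference is not broken down here. Compound 3 already stands lowest of the three in this assay, so there is little room for a further fall. The step from compound 3 to compound 4 is expected to be a number 1 percentage points lower from compound 3 to compound 4 (within the scatter), smaller than the earlier one because compound 3 starts from 3%. Compound 4 is therefore estimated at 2%, between -8% and 12%.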

Compound 4, a percentage reported as inhibition, at one concentration (the size of the read-out at that concentration, not a potency): 1%
Compound 4: middle estimate off by 1 percentage points, on the high side; measured number inside the range.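

Carried to the core of compound 3, the change from propoxy to isobutoxy gives a number 2 percentage points lower from compound 3 to compound 4 (within the scatter), so its size in this assay does not transfer from one core to the other: the same change on two cores in this assay, a number 21 percentage points lower (beyond the scatter) from compound 1 to compound 2 and a number 2 percentage points lower (within the scatter) from compound 3 to compound 4, 19 percentage points apart, beyond the scatter of two such steps. Compound 3 already gives only 3%, which leaves little room for any fall, so the small step does not show that the change is without consequence on that core. Two pairs cannot separate an effect of the core from that of the low starting value.

The compounds shown leave open how a longer chain such as butoxy, an amine or a carboxylic acid would read in place of propoxy. They also leave open which part of the difference between the two cores goes with the gap between the steps.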